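Swapping the Aryl Group on a Quinoline Thiosemicarbazone

The compounds below may be only part of what the source reports. "The series", "measured", "known", "first", "only" and "open" are said of these compounds alone.

Measured so far:
- compound 1 `Cc1ccc(NC(=O)N/N=C/c2ccc3ccccc3n2)cc1`: > 100000 nM
- compound 2 `Cc1csc2sc(/C=N/NC(N)=S)c(C)c12`: 1120 nM
- compound 3 `S=C(N/N=C/c1ccc2ccccc2n1)Nc1cccc(Br)c1`: 70000 nM

Of the compounds shown here, three have been tested in a functional assay on HeLa cells (Homo sapiens) for antiproliferative activity, read by sulforhodamine B assay, with a stated time of 72 h; a higher number here means a weaker inhibitor, a lower number a stronger inhibitor. Compound 1 gives only a limit of the assay, > 100000 nM, so no number is known for it. Compound 2 gives 1120 nM. Compound 3 gives 70000 nM, the highest of the two numbers; the gap between compound 2 and compound 3 lies beyond the scatter, so compound 3 is the weaker inhibitor of the two. Compound 1 is a reminder that some compounds of this kind sit at the limit (the limit of > 100000 nM in this assay, at which 1 of the 3 values shown sits).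

The next compound, compound 4 `COc1ccc(NC(=S)N/N=C/c2ccc3ccccc3n2)cc1`, differs from compound 3 in one place: 4-methoxyphenyl in place of 3-bromophenyl on an amide-type nitrogen. Within the data shown here, no measured pair shows the effect of such a change, so there is no step to lean on. The expectation is that compound 4 stays close to compound 3 in this assay, with a step from no change at the digits printed from compound 3 to compound 4 (within the scatter) no larger than the scatter in either direction. Compound 4 is therefore estimated at 70000 nM, within a range from 20000 nM to 200000 nM, with a real chance that only a limit is reported.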

Compound 4, half-maximal inhibitory concentration: 72600 nM
Compound 4: the middle estimate sits 1.0-fold (0.02 log units) below what was measured; the range from low to high includes it.
By their numbers in this assay, from the lowest: compound 2; then compounds 3 and 4 (each within the scatter of the next). At a limit, above all of these: compound 1.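

Among these compounds, this pair gives the first direct reading at the amide-type nitrogen whose other neighbour is the thiocarbonyl carbon, and the swap of 3-bromophenyl for 4-methoxyphenyl gives a 1.0-fold higher number from compound 3 to compound 4 (0.02 log units; within the scatter). In this assay, compound 3 and compound 4 therefore cannot be told apart, even though the incoming group brings an oxygen and a hydrogen-bond acceptor that the outgoing group lacks, and the bromine is gone. Compound 4 gives a number and not a limit, while compound 1 remains the only compound reported as a limit: the limit of > 100000 nM in this assay, at which 1 of the 4 values shown sits.

Among the compounds shown here, still, this is a single pair of substituted phenyl groups, so it shows only that these two groups cannot be separated in this assay, not that the position tolerates any change, and it gives no reason why they match. From the compounds shown here alone, it remains open whether an amine or a carboxylic acid on the phenyl ring, or a longer alkyl chain on this nitrogen in place of the ring, would move the number beyond the scatter in either direction.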